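Small side-chain changes and half-life in guinea pigs

The source may report more compounds than this note shows. Statements on the series, on what has been measured and on what is new or still open speak of the compounds shown alone.

Measured in an in vivo ADME assay on the whole organism (Cavia porcellus); on this read-out higher numbers stand for a longer-lived compound and lower numbers for a shorter-lived compound:
Compound 1 `CCC(NC(=O)c1ccc(C(=N)N)cc1)C(C)(C)C(=O)N1CCC(CC(=O)O)CC1` gives 1.3 h
Compound 2 `CCCC(NC(=O)c1ccc(C(=N)N)cc1)C(C)(C)C(=O)N1CCC(CC(=O)O)CC1` gives 0.9 h
Compound 3 `CC(C)C(NC(=O)c1ccc(C(=N)N)cc1)C(C)(C)C(=O)N1CCC(CC(=O)O)CC1` gives 0.8 h

Compound 1, at 1.3 h, cannot be separated from the other two compounds, since both of its measured steps stay within the scatter. The next compound, compound 4 `CC(C)CC(NC(=O)c1ccc(C(=N)N)cc1)C(C)(C)C(=O)N1CCC(CC(=O)O)CC1`, differs from compound 1 by isopropyl in place of methyl on a saturated chain carbon, two bonds along the chain from an amide-type nitrogen.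

Among the measured compounds shown here, three measured steps bear on this change. Enlarging the same side chain gave a 1.4-fold lower number from compound 1 to compound 2 (0.16 log units; within the scatter) and a 1.6-fold lower number from compound 1 to compound 3 (0.21 log units; within the scatter). Between the two larger chains, the data show a 1.1-fold lower number from compound 2 to compound 3 (0.05 log units; within the scatter). None of these steps leaves the scatter, although compound 4 carries a larger group than any measured compound, so the data do not fully cover it. The expected change in this assay is therefore none beyond the scatter.

The estimated step is a 1.4-fold lower number from compound 1 to compound 4 (0.16 log units; within the scatter). For compound 4 the expected half-life is 0.9 h, with an estimated range from 0.5 h to 1.5 h.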

Compound 4, half-life: 0.917 h
Estimate against measurement, compound 4: 1.0-fold (0.01 log units) below, within the range that was stated.
By their numbers in this assay, from the lowest: compounds 3, 2, 4 and 1 (each within the scatter of the next).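

In this assay, isopropyl in place of methyl on a saturated chain carbon, two bonds along the chain from an amide-type nitrogen, gives a 1.4-fold lower number from compound 1 to compound 4 (0.15 log units; within the scatter) and so shows that the largest group yet at this position still stays inside the scatter. Isobutyl also cannot be told apart from the two other enlarged chains, with a 1.1-fold higher number from compound 3 to compound 4 (0.06 log units; within the scatter) and a 1.0-fold higher number from compound 2 to compound 4 (0.01 log units; within the scatter) as its steps. Methyl in place of hydrogen on a saturated chain carbon bound to two saturated chain carbons reads alike on both chains: the same change on two cores in this assay, a 1.6-fold lower number (0.21 log units; within the scatter) from compound 1 to compound 3 and a 1.0-fold higher number (0.01 log units; within the scatter) from compound 2 to compound 4, 1.7-fold (0.22 log units) apart, within the scatter of two such steps.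

The compounds shown carry only saturated carbon chains here, so a longer chain, a phenyl ring, an amine or a hydroxyl at this position remains open. Whether any group there can move the half-life beyond the scatter also stays unanswered.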